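Amide aryl trimming on the shared core

The source may report more compounds than this note shows. Statements on the series, on what has been measured and on what is new or still open speak of the compounds shown alone.

In a functional assay on SK-MEL-2 cells (Homo sapiens) for inhibition, read by sulforhodamine B assay, with a stated time of 48 h (a higher number here means that more compound is tolerated, a lower number that less compound is tolerated), compound 1 `COc1cc(-c2nn(-c3cccc(NC(=O)Nc4cccc(C(F)(F)F)c4)c3)cc2-c2ccncc2)ccc1Cl` gives 3960 nM. Compound 2 `COc1cc(-c2nn(-c3cccc(NC(=O)c4ccc(Cl)c(C(F)(F)F)c4)c3)cc2-c2ccncc2)ccc1Cl` gives > 32500 nM in this assay, which is a limit rather than a number (the limit of > 32500 nM in this assay, at which 1 of the 2 values shown sits). Compound 3 `COc1cc(-c2nn(-c3cccc(NC(=O)c4ccccc4)c3)cc2-c2ccncc2)ccc1Cl` differs from compound 2 by phenyl in place of 4-chloro-3-(trifluoromethyl)phenyl on a carbonyl carbon. Going by the values given here, the only measured step, an at least 8.2-fold higher number from compound 1 to compound 2 (0.91 log units; beyond the scatter), also changes the group on the carbonyl carbon, but it alters the urea as well, so it bears on this change only loosely. Since compound 2 already sits at the limit, no step beyond the scatter is expected. Compound 3 is expected at 30000 nM, within 10000 nM to 70000 nM. The expected step is an at least 1.0-fold lower number from compound 2 to compound 3 (0.03 log units; that floor lies within the scatter).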

Compound 3, concentration lethal to 50% of the cells: > 100000 nM
Compound 3: only a limit was reported; the forecaster's own chance of this, stated with the estimate: 60%; at least 3.3-fold (0.52 log units) between middle value and limit.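

Compound 3, with phenyl on the carbonyl carbon, gives a limit and not a number: the limit of > 100000 nM in this assay, at which 1 of the 3 values shown sits. Replacing (3-(trifluoromethyl)phenyl)amino with phenyl on the carbonyl carbon gives an at least 25-fold higher number from compound 1 to compound 3 (1.40 log units; beyond the scatter), which leaves compound 1 as the only one of the three with a measured number. Compound 2 and compound 3 both stand as limits, so the step joining them cannot be read.

From the compounds shown here alone, it remains open whether a phenylamino group on the carbonyl carbon keeps a measurable value in this assay without the trifluoromethyl. Going by these compounds, it is also open whether an amide aryl ring carrying a dimethylamino group or a carboxylic acid would give a number rather than a limit.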